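A few compounds are considered here, and "the series" means these few. Any claim that something is new, unique, unknown or untested is made for them only; others in the source may bear on it.

Compound 1 `Cc1cccc(Nc2nc(SCc3cn(Cc4ccccc4Cl)nn3)nc(-c3ccccc3)c2C#N)c1`: in a functional assay on MCF7 cells (Homo sapiens) for inhibition, read by MTT assay, with a stated time of 72 h (on this read-out lower numbers stand for stronger inhibition and higher numbers for weaker inhibition), compound 1 gives 19600 nM.
Compound 2 `Cc1ccc(Nc2nc(SCc3cn(Cc4ccc(Cl)cc4)nn3)nc(-c3ccccc3)c2C#N)cc1`: compound 2 reaches only a limit of this assay, > 64000 nM.
Compound 3 `Cc1ccc(Nc2nc(SCc3cn(Cc4ccccc4Cl)nn3)nc(-c3ccccc3)c2C#N)cc1`: in this assay compound 3 gives 9420 nM.

Compound 3 holds the lowest of the two numbers in this assay; its nearest neighbour is compound 1, and the step of a 2.1-fold lower number from compound 1 to compound 3 (0.32 log units; beyond the scatter) is modest but beyond the scatter. Compound 2 sits at a limit (the limit of > 64000 nM in this assay, at which 1 of the 3 values shown sits), so the step of an at least 6.7-fold lower number from compound 2 to compound 3 (0.83 log units; beyond the scatter) can only be given as a floor.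

Compound 4 `COc1cc(-c2nc(SCc3cn(Cc4ccccc4Cl)nn3)nc(Nc3ccc(C)cc3)c2C#N)cc(OC)c1OC` differs from compound 3 by 3,4,5-trimethoxyphenyl in place of phenyl on an aromatic carbon. Neither measured step bears on this position: the step from compound 1 to compound 3 moves a methyl on the aryl amine, and the step from compound 2 to compound 3 moves a chlorine on the benzyl group of the triazole. Going by the values given here, the series therefore holds no precedent for the change at the aryl carbon, and no direction can be read from it.

With nothing to lean on, compound 4 is expected to land near compound 3, with the step of a 1.0-fold lower number from compound 3 to compound 4 (0.02 log units; within the scatter) estimated as within the scatter. The estimate for compound 4 in this assay is 9000 nM, with a range from 2000 nM to 45000 nM kept wide.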

Compound 4, half-maximal inhibitory concentration: 20600 nM
For compound 4 the middle estimate is 2.3-fold (0.36 log units) below the measured one; low and high end bracket the measured number.
By their numbers in this assay, from the lowest: compound 3; then compounds 1 and 4 (each within the scatter of the next). At a limit, above all of these: compound 2.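

In this assay, the aromatic carbon ortho to a cyano group now has its first measured change, and it points away from stronger inhibition: 3,4,5-trimethoxyphenyl in place of phenyl gives a 2.2-fold higher number from compound 3 to compound 4 (0.34 log units; beyond the scatter) in this series. The step is modest, although the entering group has 12 heavy atoms against 6 and 3 hydrogen-bond acceptors against 0, so this carbon carries the larger aryl group and compound 4 still gives a measured number rather than a limit. Nothing measured in the series explains the direction or the size of this step.

From the compounds shown here alone, with only phenyl and 3,4,5-trimethoxyphenyl to compare, it stays open whether the change in the number follows from the three methoxy groups together or from one of them, and a phenyl ring bearing a single methoxy, a hydroxyl, a carboxylic acid or a dimethylamino group would separate these cases. Going by these compounds, it also stays open whether the steps seen for the methyl on the aryl amine and the chlorine on the benzyl group carry over when 3,4,5-trimethoxyphenyl occupies this carbon.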